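A few compounds are considered here, and "the series" means these few. Any claim that something is new, unique, unknown or untested is made for them only; others in the source may bear on it.

Compound 1 `Nc1ccc(S(=O)(=O)N2CCN(c3ncc(C(O)(C(F)(F)F)C(F)(F)F)cc3Br)CC2)cn1` — < 14 mL.min-1.g-1
Compound 2 `Nc1ccc(S(=O)(=O)N2CCN(c3ncc(C(O)(C(F)(F)F)C(F)(F)F)cc3C3CC3)CC2)cn1` — 38 mL.min-1.g-1
Compound 3 `CS(=O)(=O)c1ccc(-c2cc(C(O)(C(F)(F)F)C(F)(F)F)cnc2N2CCN(S(=O)(=O)c3ccc(N)nc3)CC2)cc1` — 32 mL.min-1.g-1

The values come from an ADME assay (liver) for metabolic stability, with Liver microsome (Homo sapiens) as the target, using microsomes and NADPH, with a stated time of 30 min, tested at 1 uM; a higher number here means faster removal of the compound, a lower number slower removal. The value for compound 1 is a limit of the assay, not a number. Among the two numbers, compound 3 has the lowest, but its nearest neighbour is compound 2, and the gap between them (a 1.2-fold lower number from compound 2 to compound 3 (0.07 log units; within the scatter)) lies within the scatter, so the two cannot be ordered. Relative to compound 1 the steps to compound 2 (an at least 2.7-fold higher number from compound 1 to compound 2 (0.43 log units; beyond the scatter)) and to compound 3 (an at least 2.2-fold higher number from compound 1 to compound 3 (0.35 log units; beyond the scatter)) are both at least modest rises.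

Compound 4 `Nc1ccc(S(=O)(=O)N2CCN(c3ncc(C(O)(C(F)(F)F)C(F)(F)F)cc3-c3ccc4[nH]ncc4c3)CC2)cn1` differs from compound 3 in one place: 1H-indazol-5-yl in place of 4-(methylsulfonyl)phenyl on an aromatic carbon. The measured steps bearing on this change are those at the same ring carbon, namely an at least 2.2-fold higher number from compound 1 to compound 3 (0.35 log units; beyond the scatter) and a 1.2-fold lower number from compound 2 to compound 3 (0.07 log units; within the scatter); the latter, exchanging one substituent for another at this position, lies within the scatter. The expectation for compound 4 is therefore no step beyond the scatter, a 1.1-fold lower number from compound 3 to compound 4 (0.03 log units; within the scatter). Compound 4 is estimated at 30 mL.min-1.g-1, with a range from 12 mL.min-1.g-1 to 75 mL.min-1.g-1.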

Compound 4, intrinsic clearance in microsomes: 27 mL.min-1.g-1
Compound 4: the middle estimate sits 1.1-fold (0.05 log units) above what was measured; measured number inside the range.
By their numbers in this assay, from the lowest: compounds 4, 3 and 2 (each within the scatter of the next). At a limit, below all of these: compound 1.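

In this assay, 1H-indazol-5-yl is a third group at this ring carbon that cannot be told apart from the other two substituents measured there (a step of a 1.2-fold lower number from compound 3 to compound 4 (0.07 log units; within the scatter), and another a 1.4-fold lower number from compound 2 to compound 4 (0.15 log units; within the scatter)). The exchange for 4-(methylsulfonyl)phenyl brings in a hydrogen-bond donor and a five-membered aromatic ring with 2 hetero atoms, yet no step beyond the scatter follows. Unlike compounds 2 and 3, compound 4 is not clearly set apart from compound 1 (a step of an at least 1.9-fold higher number from compound 1 to compound 4 (0.28 log units; that floor lies within the scatter)), whose value is a limit of the assay: the limit of < 14 mL.min-1.g-1 in this assay, at which 1 of the 4 values shown sits.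

On these data alone, how far compound 1 actually lies from the others remains open. So does whether a methyl, a nitrile or an amine at this carbon would fall with bromo or with the other three groups.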